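The compounds below may be only part of what the source reports. "The series", "measured", "known", "first", "only" and "open" are said of these compounds alone.

In a functional assay on A549 cells (Homo sapiens) for antiproliferative activity, read by MTT assay, with a stated time of 72 h (a higher number here means a weaker inhibitor, a lower number a stronger inhibitor), the measured compounds stand as follows.
Compound 1 `COc1ncc(-c2ccc3c(c2)N(c2ccc(C)cc2)C(=O)CO3)cc1NS(=O)(=O)c1ccc(F)cc1` gives 5870 nM.
Compound 2 `COc1cccc(N2C(=O)COc3ccc(-c4cnc(Cl)c(NS(=O)(=O)c5ccc(F)cc5)c4)cc32)c1` gives 32700 nM.
Compound 3 `O=C1COc2ccc(-c3ccc(O)cc3)cc2N1` gives > 40000 nM, which is a limit of the assay and not a number.

Of the two numbers, compound 2 has the higher one, so it is the weaker inhibitor, and its gap to compound 1 lies beyond the usual scatter of repeated measurements. Compound 4 `O=C1COc2ccc(-c3cnc(Cl)c(NS(=O)(=O)c4ccc(F)cc4)c3)cc2N1c1ccc(Cl)cc1` has not yet been measured. It differs from compound 2 in one place: 4-chlorophenyl in place of 3-methoxyphenyl on an amide-type nitrogen in a ring. Among the measured compounds shown here, no measured pair shows this change on its own, so its effect is uncertain. A modest move toward a lower number, that is toward stronger inhibition, is expected, and the expected step is a 2.2-fold lower number from compound 2 to compound 4 (0.34 log units; beyond the scatter). Compound 4 is therefore estimated at 15000 nM in this assay, with a likely range from 5000 nM to 40000 nM.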

Compound 4, half-maximal inhibitory concentration: 21600 nM
Estimate against measurement, compound 4: 1.4-fold (0.16 log units) below; the measured number falls inside the stated range.
By their numbers in this assay, from the lowest: compound 1; then compounds 4 and 2 (each within the scatter of the next). At a limit, above all of these: compound 3.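

In this assay, this position is now tested directly, and the change to 4-chlorophenyl gives a 1.5-fold lower number from compound 2 to compound 4 (0.18 log units; within the scatter) so this swap of one substituted phenyl for another does not separate the two compounds. Both numbers lie fairly close under the top of what this assay reports, leaving little room to read any further weakening: the limit of > 40000 nM in this assay, at which 1 of the 4 values shown sits. As far as these compounds go, whether an amine or a carboxylic acid on this phenyl ring, or a simple alkyl chain in its place on the nitrogen, would move the number stays open.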